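This account rests on a few compounds, and the source may have more. Where it says the series, first, only, none or still open, it means among the compounds named here.

Of the compounds shown here, three of one series have been measured in a functional assay on the whole organism (blood, strain Wistar albino) for inhibition, with Rattus norvegicus as the target, read by colorimetric assay, with stated times of 15 min and 90 min, at a dose of 20 mg/kg by the oral route; a lower number here means less inhibition, a higher number more inhibition at the dose given (going by the name of the read-out). Compound 1, `Cc1ccc(-c2ccc(=O)n(-c3ccc(S(=O)(=O)NC(=O)NC4CCCCC4)cc3)n2)cc1`, gives 79.9% in this assay. Compound 2, `Cc1ccc(-c2ccc(=O)n(-c3ccc(S(=O)(=O)NC(=O)NCc4ccccc4)cc3)n2)cc1`, differs from compound 1 in one place: benzyl in place of cyclohexyl on an amide-type nitrogen. This change lowers the read-out, a number 15 percentage points lower from compound 1 to compound 2 (beyond the scatter). Compound 3, `O=C(NC1CCCCC1)NS(=O)(=O)c1ccc(-n2nc(-c3ccc(Cl)cc3)ccc2=O)cc1`, differs from compound 1 in a different place: chloro in place of methyl on an aromatic carbon. In this assay compound 3 gives 59%, and the step is also downward, a number 20.9 percentage points lower from compound 1 to compound 3 (beyond the scatter). Compound 2 gives 64.9% in this assay, and its value and that of compound 3 lie within the scatter of each other, so no order between them can be read.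

Compound 4, `O=C(NCc1ccccc1)NS(=O)(=O)c1ccc(-n2nc(-c3ccc(Cl)cc3)ccc2=O)cc1`, has not been measured. It differs from compound 3 exactly as compound 2 differs from compound 1: benzyl in place of cyclohexyl on an amide-type nitrogen. The two cores differ as described for compound 1 and compound 3, and the place of the change is the same in both pairs, so this is the same change made a second time. For compound 4 a downward step of about the size seen for the first pair is expected, because the earlier step was a number 15 percentage points lower from compound 1 to compound 2 (beyond the scatter) and the starting point here is the value of compound 3, 59%, which gives an expected step of a number 14 percentage points lower from compound 3 to compound 4 (beyond the scatter). Whether the change carries over unchanged onto the other core is not known from these three compounds, so the range is kept wide. Compound 4 is estimated to give 45% in this assay, expected between 30% and 60%.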

Compound 4, a percentage reported as inhibition, in the whole organism at one dose (the size of the read-out at that dose, not a potency): 61.6%
The estimate for compound 4 lay 16.6 percentage points below the measured number, and the stated range ends below it.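

In this assay, putting benzyl in place of cyclohexyl on the amide-type nitrogen of the core of compound 3 gave a number 2.6 percentage points higher from compound 3 to compound 4 (within the scatter), and this step does not match the one seen on the core of compound 1: the same change on two cores in this assay, a number 15 percentage points lower (beyond the scatter) from compound 1 to compound 2 and a number 2.6 percentage points higher (within the scatter) from compound 3 to compound 4, 17.6 percentage points apart, beyond the scatter of two such steps. Read the other way round, chloro in place of methyl on an aromatic carbon gave a number 3.3 percentage points lower from compound 2 to compound 4 (within the scatter), and this step does not match its counterpart either: the same change on two cores in this assay, a number 20.9 percentage points lower (beyond the scatter) from compound 1 to compound 3 and a number 3.3 percentage points lower (within the scatter) from compound 2 to compound 4, 17.6 percentage points apart, beyond the scatter of two such steps. The four compounds thus show that in this series neither change carries over from one core to the other as a fixed step, since each lowers the read-out only when made on compound 1, but they rest on a single pair of cores at one dose and do not show why the steps differ or how the change would behave on any further core.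

The compounds shown leave open whether other groups on that nitrogen, such as a straight butyl chain or a phenylethyl group, would follow the cyclohexyl or the benzyl compounds on either core. They also leave open whether a methoxy group or a fluorine atom in place of the methyl or chloro would leave the benzyl step as small as it is on the core of compound 3.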